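A few compounds are considered here, and "the series" means these few. Any claim that something is new, unique, unknown or untested is made for them only; others in the source may bear on it.

Measured so far in a physicochemical assay for lipophilicity; on this read-out higher numbers stand for higher lipophilicity and lower numbers for lower lipophilicity

- compound 1 `CCn1nc(Cn2nnc(-c3ccccn3)n2)cc1C` gives 2.08
- compound 2 `Cc1cc(Cn2nnc(-c3ccccn3)n2)n[nH]1` gives 1.69

For the measured compounds named here, compound 1 holds the higher of these two numbers, and compound 2 is its only neighbour. The next structure, compound 3 `CCn1nc(Cn2nnc(Cc3ccccc3)n2)cc1C`, has benzyl in place of pyridin-2-yl on an aromatic carbon of the shared core (benzyl in place of pyridin-2-yl on an aromatic carbon). Going by the values given here, only one measured step offers any guide. That step, a number 0.39 log units lower from compound 1 to compound 2 (beyond the scatter), put hydrogen in place of ethyl on an aromatic nitrogen, at a different place, so it bears only loosely on this change. There, carbon left and the number fell. Here, carbon enters and a ring nitrogen leaves, so a rise in this assay is expected, probably larger than that modest step. The estimate is a number 0.82 log units higher from compound 1 to compound 3 (beyond the scatter) overall. For compound 3 the expected value is 2.9, with an estimated range from 2.4 to 3.4.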

Compound 3, partition coefficient: 2.88
For compound 3 the middle estimate is 0.02 log units above the measured one, within the range that was stated.
By their numbers in this assay, from the lowest: compound 2; then compound 1; then compound 3.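

For the compounds shown here, the earlier pair showed a change only on an aromatic nitrogen, whereas this result is the first reading for the aromatic carbon of the five-membered aromatic ring with 4 nitrogen. Putting benzyl in place of pyridin-2-yl there gives a number 0.80 log units higher from compound 1 to compound 3 (beyond the scatter) in this assay and shows that this position, too, can move the number beyond the scatter. No supporting measurement says what lies behind the rise.

Benzyl differs from pyridin-2-yl in two ways at once, with one ring nitrogen gone and the heavy-atom count going from 6 to 7, and a single step cannot divide the rise between these differences. Phenyl or pyridin-2-ylmethyl at this position would each change only one of them, and the compounds shown include neither group.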